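Bromo to methoxy on the aryl of the sulfamide series

The compounds below may be only part of what the source reports. "The series", "measured", "known", "first", "only" and "open" are said of these compounds alone.

Working notes on a small set of hydroxamic acids with a shared sulfamide core. Compound 1 `O=C(NO)[C@H]1CCCCN1S(=O)(=O)N1CC=C(c2ccc(Cl)cc2)CC1` is the best-characterised member: in a functional assay on MONO-MAC-6 cells (Homo sapiens) for inhibition (on this read-out lower numbers stand for stronger inhibition and higher numbers for weaker inhibition), compound 1 gives 430 nM; 480 nM (2 entries), and the agreement between its repeats the several entries of compound 1 in this assay, 430 nM; 480 nM (2 entries) shows the run-to-run spread for this read-out. Within the data shown here, compound 2 `O=C(NO)[C@H]1CCCCN1S(=O)(=O)N1CC=C(c2ccc(Br)cc2)CC1` carries the bromo group in the same place; in this assay compound 2 gives 1200 nM, the only number recorded for it, with one further entry that yielded no single value.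

Compound 3 `COc1ccc(C2=CCN(S(=O)(=O)N3CCCC[C@@H]3C(=O)NO)CC2)cc1` is the next analogue, not yet measured. Relative to compound 2 the change is methoxy in place of bromo on an aromatic carbon. Among the measured compounds shown here, no measured pair in the set reports this kind of exchange, so the expected step of a 1.5-fold lower number from compound 2 to compound 3 (0.18 log units; within the scatter) is set small, towards stronger inhibition, and may well fall within the scatter. For compound 3 the estimate in this assay is 800 nM, with a range from 300 nM to 2500 nM.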

Compound 3, half-maximal inhibitory concentration: 15000 nM
For compound 3 the middle estimate is 19-fold (1.27 log units) below the measured one; the measured number lies above the stated range.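

In this assay, methoxy in place of bromo on this aromatic carbon gives a 13-fold higher number from compound 2 to compound 3 (1.10 log units; beyond the scatter), so the read-out is clearly sensitive to the group at this place, para to a large group. The earlier compounds shown here, with chloro in compound 1 and bromo in compound 2, gave no view of a change of this size, and this one is small by count, with bromo leaving and methoxy entering. The step stands well clear of the run-to-run spread seen in the repeats: the several entries of compound 1 in this assay, 430 nM; 480 nM (2 entries).

The compounds shown do not tell which feature of methoxy goes with the step, as the oxygen and the added carbon enter together. As far as these compounds go, it also remains open whether a methyl, an amine or a carboxylic acid on this carbon would read close to compound 2 or close to compound 3.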